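The compounds below may be only part of what the source reports. "The series", "measured", "known", "first", "only" and "open" are said of these compounds alone.

Measured compounds in a functional assay on MDA-MB-435 cells (Homo sapiens) for cytotoxicity, read by MTT assay, with a stated time of 72 h; on this read-out higher numbers stand for weaker inhibition and lower numbers for stronger inhibition:
- compound 1 `O=C(NCc1ccc(F)cc1)c1nc(Br)c2cccnc2c1NCCCNc1c(C(=O)NCc2ccc(F)cc2)nc(Br)c2cccnc12` gives > 20000 nM, a limit of the assay
- compound 2 `O=C(NCc1ccc(F)cc1)c1nc(Br)c2cccnc2c1NCc1ccccc1` gives > 20000 nM, a limit of the assay
- compound 3 `N[C@H]1CC[C@H](Nc2c(C(=O)NCc3ccc(Cl)cc3)nc(Br)c3cccnc23)CC1` gives 1000 nM

Compound 2 stands at the limit of > 20000 nM in this assay, at which 2 of the 3 values shown sit, and therefore has no number, only the knowledge that whatever inhibition it shows lies beyond the range measured. Within the data shown here, compound 3 is the only compound of the three with a numerical value, and it carries a very different amine side chain, so it offers no direct step to either of the others. Among the measured compounds shown here, no pair of measured compounds differs in a single place, and the change toward compound 4 has no measured precedent.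

Compound 4 `C[C@@H](Nc1c(C(=O)NCc2ccc(F)cc2)nc(Br)c2cccnc12)c1ccccc1` differs from compound 2 by methyl in place of hydrogen on a saturated chain carbon bound to an aromatic carbon and a nitrogen on an aromatic ring. The change is small and adds only a methyl on the chain carbon that joins the benzyl group to the amine. Without any measured step to lean on, no movement beyond the scatter is expected; the step from compound 2 to compound 4 is expected to be a number no higher from compound 2 to compound 4 (the limit leaves the size open) in this assay. Compound 4 is accordingly expected to give about 20000 nM, with a range of 5000 nM to 60000 nM, and a limit rather than a number is the more probable outcome.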

Compound 4, half-maximal inhibitory concentration: > 20000 nM
Compound 4: only a limit was reported; the forecaster's own chance of this, stated with the estimate: 70%; the middle value lies on the limit itself.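

Compound 2 and compound 4 both sit at a limit and carry no number, so no step can be read between them: the limit of > 20000 nM in this assay, at which 3 of the 4 values shown sit.

Going by these compounds, whether methyl in place of hydrogen on this chain carbon changes inhibition in either direction remains open.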